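The compounds below may be only part of what the source reports. "The series", "measured", "known", "first", "only" and "open" are said of these compounds alone.

Measured compounds, with half-maximal inhibitory concentration in an assay on HEK293 cells for negative allosteric modulation of metabotropic glutamate receptor 5 (Homo sapiens), read by FLIPR, with a stated time of 1 h; on this read-out lower numbers stand for stronger inhibition and higher numbers for weaker inhibition:

compound 1 `CCN1CCc2nc(C#Cc3ccccc3)sc2C1`: 1200 nM
compound 2 `O=S(=O)(C1CC1)N1CCc2nc(C#Cc3ccccc3)sc2C1`: 34 nM

For the measured compounds named here, compound 2 holds the lowest of the two numbers in this assay; its only neighbour is compound 1, and the single measured step, a 35-fold lower number from compound 1 to compound 2 (1.55 log units; beyond the scatter), is the full extent of what is known so far.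

Compound 3 `O=C(N1CCCCC1)N1CCc2nc(C#Cc3ccccc3)sc2C1` is the next member. The change from compound 2 is (piperidin-1-yl)carbonyl in place of cyclopropylsulfonyl on an amine nitrogen in a ring. Going by the values given here, no measured step covers an exchange of one group for another on this nitrogen; the one step available, a 35-fold lower number from compound 1 to compound 2 (1.55 log units; beyond the scatter), concerns the move from ethyl to cyclopropylsulfonyl and is large. Since compound 3 keeps a carbonyl-bearing group on that nitrogen rather than returning to an alkyl, the expected step is small, a 2.1-fold higher number from compound 2 to compound 3 (0.31 log units; beyond the scatter), with the number for compound 3 estimated at 70 nM, between 15 nM and 300 nM.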

Compound 3, half-maximal inhibitory concentration: > 10000 nM
Compound 3 gave a limit, no number (the forecaster's own chance of this, stated with the estimate: 3%); middle value at least 140-fold (2.15 log units) from the limit.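

In this assay compound 3 gives a limit of the assay and not a number: the limit of > 10000 nM in this assay, at which 1 of the 3 values shown sits. The step of an at least 290-fold higher number from compound 2 to compound 3 (2.46 log units; beyond the scatter) shows that the group on this amine nitrogen in a ring can decide the read-out, even though both groups carry no net charge and no hydrogen-bond donors. The step of an at least 8.3-fold higher number from compound 1 to compound 3 (0.92 log units; beyond the scatter) shows that the two non-alkyl groups part in direction from ethyl: cyclopropylsulfonyl gives the lower number and (piperidin-1-yl)carbonyl the higher one, so leaving ethyl does not by itself give a lower number.

The compounds shown leave open whether the loss follows the carbonyl in place of the sulfonyl or the piperidine ring, since both change together here. A cyclopropylcarbonyl group or a piperidin-1-ylsulfonyl group on this nitrogen would separate the two.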